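Swapping acetyl for methyl on a ring oxygen

This account rests on a few compounds, and the source may have more. Where it says the series, first, only, none or still open, it means among the compounds named here.

Measured so far:
compound 1 `CCCCc1c(CCCC)c(OC(C)=O)c2ccccc2c1OC`: 6020 nM
compound 2 `CCCCc1c(C)c(OC)c2ccccc2c1OC(C)=O`: 200 nM
compound 3 `CCCCc1cc(OC)c2ccccc2c1OC(C)=O`: 440 nM

In a functional assay for inhibition, with Rattus norvegicus as the target (on this read-out lower numbers stand for stronger inhibition and higher numbers for weaker inhibition), compound 3 gives 440 nM, the middle of the three numbers, with compound 2 lower and compound 1 much higher.

Compound 4 `CCCCc1cc(OC)c2ccccc2c1OC` keeps the core of compound 3 and alters one group: methyl in place of acetyl on an oxygen on an aromatic ring. In words, this is methyl in place of acetyl on an oxygen on an aromatic ring, so acetoxy becomes methoxy.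

For the measured compounds named here, none of the measured steps touches the acetyl, so none of them shows the direction of this change. They show only how far a single change can move the number here, from modest in a 2.2-fold higher number from compound 2 to compound 3 (0.34 log units; beyond the scatter) to large in a 30-fold lower number from compound 1 to compound 2 (1.48 log units; beyond the scatter) and a 14-fold lower number from compound 1 to compound 3 (1.14 log units; beyond the scatter). The direction expected here, towards weaker inhibition, is therefore a judgement, and the range must stay wide. The estimated change is a 3.4-fold higher number from compound 3 to compound 4 (0.53 log units; beyond the scatter). The estimate for compound 4 is 1500 nM, with an expected range from 300 nM to 8000 nM.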

Compound 4, half-maximal inhibitory concentration: 40900 nM
Compound 4: middle estimate off by 27-fold (1.44 log units), on the low side, outside the stated range (above it).
By their numbers in this assay, from the lowest: compound 2; then compound 3; then compound 1; then compound 4.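

In this assay the acetyl on the ring oxygen turns out to matter a great deal: methyl in its place gives a 93-fold higher number from compound 3 to compound 4 (1.97 log units; beyond the scatter) and moves the number towards much weaker inhibition. For the compounds shown here, compounds 1, 2 and 3 all keep the acetyl and differ only in the chains and the methyl on the ring carbons, so this is the first step that shows the direction of a change at this oxygen, and its size is large. No measurement at hand explains why acetoxy and methoxy differ so strongly here.

A free hydroxyl, a propionyl or a carbamate on this oxygen would show whether the acetyl itself counts or whether other groups can stand in for it. On these data alone, whether the same swap has a similar effect in compound 2 or compound 1, with their further chains on the ring, also remains open.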